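Thienyl series: aryl and bromo variation at the ring sulfur

The source may report more compounds than this note shows. Statements on the series, on what has been measured and on what is new or still open speak of the compounds shown alone.

Measured so far in an assay on CHO cells for displacement of a labelled ligand from adenosine receptor A3 (Homo sapiens), read by scintillation counting, tested at 10 uM; on this read-out higher numbers stand for more inhibition at the one concentration tested (going by the name of the read-out) and lower numbers for less inhibition:
compound 1, `CC(C)(C)Cc1c(-c2ccncc2)sc(N)c1C(=O)c1ccc(Cl)cc1`, 6%
compound 2, `COc1ccccc1-c1sc(N)c(C(=O)c2ccc(Cl)cc2)c1CC(C)(C)C`, 1%
compound 3, `CC(C)(C)Cc1c(Br)sc(N)c1C(=O)c1ccc(Cl)cc1`, 1%

All three compounds share the same core and differ only in the group on the aromatic carbon next to the ring sulfur. The steps between them are small: a number 5 percentage points lower from compound 1 to compound 2 (within the scatter), a number 5 percentage points lower from compound 1 to compound 3 (within the scatter) and no change at the digits printed from compound 2 to compound 3 (within the scatter). None of them is beyond the scatter, so the three values cannot be placed in an order. Compound 3 is level with compound 2 at the digits printed, the two together giving the lowest numbers of the three, and its gap to the remaining compound is a number 5 percentage points lower from compound 1 to compound 3 (within the scatter), which is still within the scatter.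

Compound 4, `CC(C)(C)Cc1c(-c2ccccc2)sc(N)c1C(=O)c1ccc(Cl)cc1`, has not yet been measured in this assay. It differs from compound 3 as follows: phenyl in place of bromo on an aromatic carbon.

Going by the values given here, the steps that bear on this change are those in which a six-membered aromatic group stood in the same place, a number 5 percentage points lower from compound 1 to compound 3 (within the scatter) and no change at the digits printed from compound 2 to compound 3 (within the scatter), both within the scatter. A phenyl in that place is therefore expected to leave the read-out essentially unchanged, with a step of a number 2 percentage points higher from compound 3 to compound 4 (within the scatter) expected. For compound 4 the estimate in this assay is 3%, with a range from -8% to 14%.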

Compound 4, a percentage reported as inhibition, at one concentration (the size of the read-out at that concentration, not a potency): 1%
For compound 4 the middle estimate is 2 percentage points above the measured one; measured number inside the range.
By their numbers in this assay, from the lowest: compounds 2, 3, 4 and 1 (each within the scatter of the next).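

Working notes on the group next to the ring sulfur: in this assay, an unsubstituted phenyl now stands in this place, and the larger aromatic ring of six carbons in place of bromo gives no change at the digits printed from compound 3 to compound 4 (within the scatter). The two earlier aryl groups can now each be compared with this plain phenyl: hydrogen in place of the methoxy gives no change at the digits printed from compound 2 to compound 4 (within the scatter), while phenyl in place of pyridin-4-yl gives a number 5 percentage points lower from compound 1 to compound 4 (within the scatter), so in this set neither the methoxy nor the change from pyridin-4-yl to phenyl separates from the scatter, and the four compounds cannot be put in an order. No measurement at hand accounts for these numbers.

Still open, going by these compounds, is whether any group in this place moves the read-out beyond the scatter, for example a piperidine, a carboxylic acid or a longer alkyl chain, or a phenyl carrying an amine. Also open, on these data alone, is whether changes to the neopentyl group, the amino group or the 4-chlorobenzoyl group would give a different result, as all four compounds share these and a single-concentration read-out gives no potency.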